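Swapping cyclohexylamino for butoxy: expected cell tolerance

This account rests on a few compounds, and the source may have more. Where it says the series, first, only, none or still open, it means among the compounds named here.

Measured so far:
Compound 1, `COCCOc1nc(N)nc2c1ncn2/C=C1/CC1(CO)CO`: > 20000 nM
Compound 2, `Nc1nc(NC2CCCCC2)c2ncn(/C=C3/CC3(CO)CO)c2n1`: "not determined" (no result reported)

Two compounds sharing a core have been examined in an ADME assay on MOLT-3 cells (Homo sapiens) for cytotoxicity, with a stated time of 7 days; a lower number here means that less compound is tolerated, a higher number that more compound is tolerated. Compound 1 reaches only the limit of this assay, where it gives > 20000 nM, so no number is known for it. Compound 2 stands without a number: in this assay it gives "not determined" (no result reported), and no result was reported. Going by the values given here, the one value shown is therefore (the limit of > 20000 nM in this assay, at which 1 of the 2 values shown sits), and nothing else has been placed on the scale.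

The step from compound 2 to compound 3, `CCCCOc1nc(N)nc2c1ncn2/C=C1/CC1(CO)CO`, exchanges one group on the core: butoxy in place of cyclohexylamino on an aromatic carbon. Among the compounds with values here, no measured step between two compounds is available, so the size of this change cannot be read from the data; the expectation is that compound 3 shows no step beyond the scatter of this assay, since compound 1, carrying a different alkoxy group in the same kind of position, sits at the limit with > 20000 nM. Compound 3 is expected to give about 30000 nM, within a range of 10000 nM to 100000 nM, most likely reported again as a limit rather than a number.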

Compound 3, half-maximal cytotoxic concentration: > 20000 nM
Compound 3 gave a limit, no number; the forecaster's own chance of this, stated with the estimate: 75%; the middle value does not contradict the limit.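

No new step can be read from compound 1 to compound 3, as neither has a number on the scale: the limit of > 20000 nM in this assay, at which 2 of the 3 values shown sit.

The compounds shown leave open where compound 1 and compound 3 truly lie, and how a cyclohexylamino group compares with butoxy in this assay.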